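Lengthening a Hydroxyalkyl Carbonate Chain on a Shared Core

This account rests on a few compounds, and the source may have more. Where it says the series, first, only, none or still open, it means among the compounds named here.

Compound 1 `Cc1cn(C2CC(N=[N+]=[N-])C(COC(=O)NCCCO)O2)c(=O)[nH]c1=O` — > 50000 nM
Compound 2 `Cc1cn(C2CC(N=[N+]=[N-])C(COC(=O)OCCCCO)O2)c(=O)[nH]c1=O` — > 50000 nM

In a functional assay on MT4 cells (Homo sapiens) for cytotoxicity (on this read-out lower numbers stand for higher toxicity in this test and higher numbers for lower toxicity in this test), compound 1 gives > 50000 nM, which is a limit of the assay and not a number. In this assay compound 2 gives > 50000 nM, again a limit of the assay. Going by the values given here, the single measured step, a step that the two limits leave unreadable from compound 1 to compound 2, is therefore unreadable in size. Among the compounds with values here, compound 2 stands at the limit, and the one further value shown sits at the same limit (the limit of > 50000 nM in this assay, at which 2 of the 2 values shown sit).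

Compound 3 `Cc1cn(C2CC(N=[N+]=[N-])C(COC(=O)OCCCCCCO)O2)c(=O)[nH]c1=O` differs from compound 2 by 2-hydroxyethyl in place of hydroxy on a saturated chain carbon, four bonds along the chain from an oxygen next to a carbonyl group. Within the data shown here, no measured step bears on this change with a readable size; the only step available, from compound 1 to compound 2, is bounded on both sides. The account therefore expects no step beyond the scatter, a number no higher from compound 2 to compound 3 (the limit leaves the size open), and it estimates compound 3 at 50000 nM in this assay, within a range from 20000 nM to 100000 nM, most likely reported again only as a limit.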

Compound 3, half-maximal cytotoxic concentration: > 50000 nM
Compound 3: a limit, no number; the forecaster's own chance of this, stated with the estimate: 80%; the middle value sits exactly at the limit.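

In this assay, going by these compounds alone, compound 3 gives > 50000 nM, a limit of the assay and not a number, so no step among compound 1, compound 2 and compound 3 can be read. The three compounds share one position: the limit of > 50000 nM in this assay, at which 3 of the 3 values shown sit.

The compounds shown leave open whether the length of the hydroxyalkyl chain, or the change from (3-hydroxypropyl)amino to an alkoxy group, alters the read-out in this assay.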